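The source may hold more compounds than are shown below. What is called first, only, known or untested is meant among the compounds shown, and "the series" means these compounds.

Cytotoxicity notes on the series. Compound 2 `Cc1ccccc1NC(=O)/C=C/c1coc2cc(O)ccc2c1=O` gives 374000 nM in an ADME assay on HepG2 2.2.15 cells (Homo sapiens) for cytotoxicity, read by MTT assay, with stated times of 48 h and 9 days; a lower number here means that less compound is tolerated, a higher number that more compound is tolerated; compound 1 `COc1ccc2c(=O)c(/C=C/C(=O)Nc3ccccc3)coc2c1` gives 523000 nM in this assay, and the two numbers lie within the scatter of each other, so neither compound is set apart. Compound 3 `O=C(/C=C/c1coc2cc(O)ccc2c1=O)Nc1ccccc1` is the next candidate; its change from compound 2 is hydrogen in place of methyl on an aromatic carbon. Among the compounds with values here, no measured pair covers this change, and the two numbers seen so far spread little, so no step in this assay beyond the scatter is expected in either direction. For compound 3 the expected value is 400000 nM, with a range from 200000 nM to 800000 nM. The expected step is a 1.1-fold higher number from compound 2 to compound 3 (0.03 log units; within the scatter).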

Compound 3, half-maximal cytotoxic concentration: 821000 nM
For compound 3 the middle estimate is 2.1-fold (0.31 log units) below the measured one, and the stated range ends below it.
By their numbers in this assay, from the lowest: compounds 2, 1 and 3 (each within the scatter of the next, the first and the last beyond it).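

In this assay, within the data shown here, going from the 2-methylphenyl group to phenyl is the first single change to pass the scatter (a 2.2-fold higher number from compound 2 to compound 3 (0.34 log units; beyond the scatter)). A methyl on this aromatic carbon, ortho to a large group, therefore goes with less compound tolerated, though this rests on one pair. The methyl on the oxygen on the aromatic ring gives no such separation (a 1.6-fold higher number from compound 1 to compound 3 (0.20 log units; within the scatter)).

As far as these compounds go, whether a longer chain or an amine on this aromatic carbon would shift the number, and in which direction, stays open. Nothing at hand gives a cause for either step.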